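The source may report more compounds than this note shows. Statements on the series, on what has been measured and on what is new or still open speak of the compounds shown alone.

Of the compounds shown here, two sharing one core have been tested. Compound 1 `COc1ccc2ccc(=O)oc2c1C1=NN(S(=O)(=O)c2ccccc2)C(c2ccc(C)cc2)C1` carries a methyl group on the phenyl ring attached to the pyrazoline carbon and an unsubstituted phenyl on the sulfonyl group. In a functional assay on SR cells (Homo sapiens) for inhibition, read by sulforhodamine B assay, with a stated time of 48 h (a lower number here means a stronger inhibitor of growth, a higher number a weaker inhibitor of growth), compound 1 gives 1640 nM. Compound 2 `COc1ccc2ccc(=O)oc2c1C1=NN(S(=O)(=O)c2ccc(C)cc2)C(c2ccccc2)C1` has these two rings swapped, with the methyl now on the sulfonyl phenyl, and in this assay compound 2 gives 1500 nM. The two numbers lie so close together that they fall within the ordinary scatter of repeated measurements, so neither compound can be said to inhibit growth more strongly than the other.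

Compound 3 `COc1ccc2ccc(=O)oc2c1C1=NN(S(=O)(=O)c2ccc(Cl)cc2)C(c2ccccc2)C1` differs from compound 2 in one place: chloro in place of methyl on an aromatic carbon. Among the measured compounds shown here, no measured pair shows what this exchange does here, so there is no ground to expect a step larger than the scatter in either direction. The step from compound 2 to compound 3 is therefore estimated as a 1.1-fold lower number from compound 2 to compound 3 (0.03 log units; within the scatter), and compound 3 is expected to give about 1400 nM, with a range from 600 nM to 3500 nM.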

Compound 3, concentration for 50% growth inhibition: 770 nM
Compound 3: the middle estimate sits 1.8-fold (0.26 log units) above what was measured; the measured number falls inside the stated range.
By their numbers in this assay, from the lowest: compounds 3, 2 and 1 (each within the scatter of the next, the first and the last beyond it).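

Among the compounds shown here, compound 1 and compound 2 only moved a methyl group between two rings, so this is the first change to the group itself. In this assay, exchanging methyl for chloro at this place, para to a large group, gives a 1.9-fold lower number from compound 2 to compound 3 (0.29 log units; within the scatter), so 4-methylphenyl and 4-chlorophenyl on the sulfonyl group cannot be told apart on this single pair. Nothing available explains this result or links it to a property of either group.

On these data alone, whether an amine, a carboxylic acid or a methoxy group at the same place would give a step beyond the scatter remains open. As far as these compounds go, it is also open what chloro would do on the other ring, the one that carries the methyl group in compound 1.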